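Replacing the 2-chloro with propylamino on the dichlorobenzimidazole core

The compounds below may be only part of what the source reports. "The series", "measured", "known", "first", "only" and "open" are said of these compounds alone.

Measured so far:
compound 1 `C[C@@H]1O[C@@H](n2c(Br)nc3cc(Cl)c(Cl)cc32)[C@H](O)[C@@H]1O`: 60000 nM
compound 2 `C[C@@H]1O[C@@H](n2c(Cl)nc3cc(Cl)c(Cl)cc32)[C@H](O)[C@@H]1O`: 60000 nM

In a functional assay on KB cells (Homo sapiens) for inhibition (on this read-out higher numbers stand for weaker inhibition and lower numbers for stronger inhibition), compound 2 gives 60000 nM, level with compound 1. Going by the values given here, the only measured step, no change at the digits printed from compound 1 to compound 2 (within the scatter), swaps one halogen for another and tells nothing about an amine entering. Compound 3 `CCCNc1nc2cc(Cl)c(Cl)cc2n1[C@@H]1O[C@@H](C)[C@@H](O)[C@H]1O` differs from compound 2 by propylamino in place of chloro on an aromatic carbon. Among the compounds with values here, no measured step bears on this change, so the direction is open; the shared weak level of compounds 1 and 2 leaves room mainly downward in concentration. Compound 3 is therefore expected at 30000 nM, in a wide range from 5000 nM to 60000 nM, an expected step of a 2.0-fold lower number from compound 2 to compound 3 (0.30 log units; within the scatter).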

Compound 3, half-maximal inhibitory concentration: 65000 nM
Estimate against measurement, compound 3: 2.2-fold (0.34 log units) below; measured number outside the range, above it.
By their numbers in this assay, from the lowest: compounds 1, 2 and 3 (each within the scatter of the next).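

In this assay propylamino in place of chloro on this aromatic carbon gives a 1.1-fold higher number from compound 2 to compound 3 (0.03 log units; within the scatter) and propylamino in place of bromo gives a 1.1-fold higher number from compound 1 to compound 3 (0.03 log units; within the scatter). The earlier compounds shown here compared only one halogen with another, whereas these steps show that at this position, between two ring nitrogen atoms, a propylamino group leaves the number level with both halogens. Nothing measured here accounts for this result. The compounds shown leave open whether an unsubstituted amine, a longer chain or a carboxylic acid on this carbon would move the number away from this level.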